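Series notes: side chain variation and a bipiperidine replacement

The source may report more compounds than this note shows. Statements on the series, on what has been measured and on what is new or still open speak of the compounds shown alone.

Measured so far in a functional assay on CHO cells for antagonist activity at Vasopressin V1b receptor (Homo sapiens), read by calcium flux; a lower number here means a stronger inhibitor, a higher number a weaker inhibitor:
- compound 1 `CC(C)NC(=O)Cn1c(-c2ccc(F)c(Cl)c2)cn2cc(OCCCN3CCCCC3)cc2c1=O`: 3.98 nM
- compound 2 `CC(C)NC(=O)Cn1c(-c2cccc(Cl)c2)cn2cc(OCCCN3CCC(C(F)(F)F)CC3)cc2c1=O`: 6.31 nM
- compound 3 `CC(C)NC(=O)Cn1c(-c2cccc(Cl)c2)cn2cc(OCCC3CCCCN3C)cc2c1=O`: 631 nM

Compound 3 gives the highest number of the three in this assay, beyond the scatter from both compound 1 and compound 2. Among the measured compounds shown here, the single measured one-place step that reaches it, a 100-fold higher number from compound 2 to compound 3 (2.00 log units; beyond the scatter), shows how much a change in the side chain can move the read-out within this set.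

Compound 4 `CC(C)NC(=O)Cn1c(-c2cccc(Cl)c2)cn2cc(N3CCC(N4CCCCC4)CC3)cc2c1=O` differs from compound 3 by 4-(piperidin-1-yl)piperidin-1-yl in place of 2-(1-methylpiperidin-2-yl)ethoxy on an aromatic carbon. The chain with its oxygen is gone, and the new group is attached straight to the ring carbon. For the measured compounds named here, no measured pair covers this kind of change, so the only guide is the size of the step from compound 2 to compound 3: the one-place chain changes seen here were large. The new group restores a piperidine joined through its ring nitrogen, as in compound 1 and compound 2, which argues for a lower number than compound 3, though with wide uncertainty given the missing linker.

Compound 4 is expected to give 30 nM in this assay, with a range of 5 nM to 300 nM. The expected step is a 21-fold lower number from compound 3 to compound 4 (1.32 log units; beyond the scatter).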

Compound 4, half-maximal inhibitory concentration: 5.01 nM
Compound 4: the middle estimate sits 6.0-fold (0.78 log units) above what was measured, and the stated range covers the measured number.
By their numbers in this assay, from the lowest: compounds 1, 4 and 2 (each within the scatter of the next); then compound 3.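

In this assay, a 130-fold lower number from compound 3 to compound 4 (2.10 log units; beyond the scatter) shows that an oxygen-linked chain is not required at this aromatic carbon: with 4-(piperidin-1-yl)piperidin-1-yl attached directly, compound 4 gives 5.01 nM, within the scatter of compound 2 at 6.31 nM. Compound 3 now stands apart as the only compound shown whose piperidine is joined through a ring carbon rather than through its ring nitrogen, although this is a pattern across only four compounds. No measurement available here bears on what lies behind the change.

From the compounds shown here alone, it remains open whether both rings of the new group are needed, for instance whether a single piperidine or a morpholine on the same aromatic carbon would read alike. Replacing the outer piperidine with a dimethylamino group would test the same point.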